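Fluoro for methyl on the outer phenyl ring

This account rests on a few compounds, and the source may have more. Where it says the series, first, only, none or still open, it means among the compounds named here.

In an ADME assay on L02 cells (Homo sapiens) for cytotoxicity, read by MTT assay, with a stated time of 24 h (on this read-out lower numbers stand for higher toxicity in this test and higher numbers for lower toxicity in this test), compound 3 (`Cc1ccc(-n2cc(-c3ccc(NS(=O)(=O)c4c[nH]c(=O)[nH]c4=O)cc3)nn2)cc1`) is reported only as "not toxic" (no number reported) without a single number, and it is not the only one: compound 1 (`O=c1[nH]cc(S(=O)(=O)Nc2cccc(-c3cn(-c4cccc(F)c4)nn3)c2)c(=O)[nH]1`) likewise gives "not toxic" (no number reported) in this assay with no number attached. The one figure available comes from compound 2 (`O=c1[nH]cc(S(=O)(=O)Nc2cccc(-c3cn(-c4cccc(Cl)c4)nn3)c2)c(=O)[nH]1`), which in this assay gives 8330 nM. Compound 3 therefore cannot be placed against compound 2 on the scale, since it has no number to compare.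

Compound 4 (`O=c1[nH]cc(S(=O)(=O)Nc2ccc(-c3cn(-c4ccc(F)cc4)nn3)cc2)c(=O)[nH]1`) differs from compound 3 in one place: fluoro in place of methyl on an aromatic carbon. Within the data shown here, with no step between two measured compounds available, the size of any shift in this assay is unknown; the expectation is for no change beyond the usual scatter, with the read-out again most likely to come back without a number. The estimate for compound 4 in this assay is 20000 nM, within a range of 8000 nM to 60000 nM, with the measured value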

Compound 4, half-maximal cytotoxic concentration: "not toxic" (no number reported)
For compound 4 the study gives words and no number; there is nothing to compare the estimate with.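

In this assay, among these compounds, compound 3 and compound 4 are both reported in words alone, so no step between them can be read. The compounds shown leave open what shift, if any, the change from 4-methylphenyl to 4-fluorophenyl brings. No further evidence bears on this result.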